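The compounds below may be only part of what the source reports. "The series", "measured", "known", "first", "only" and "open" are said of these compounds alone.

Measured so far in an assay on CHO cells for displacement of a labelled ligand from adenosine receptor A1 (Homo sapiens), read by scintillation counting, with a stated time of 120 min, tested at 10 uM; a higher number here means more inhibition at the concentration tested (going by the name of the read-out), a lower number less inhibition:

Compound 1, `Nc1scc(CN2CCN(c3ccc(Cl)c(C(F)(F)F)c3)CC2)c1C(=O)c1ccc(Cl)cc1`, gives 0%.
Compound 2, `Nc1scc(CN2CCN(c3ccncc3)CC2)c1C(=O)c1ccc(Cl)cc1`, gives 1%.
Compound 3, `Nc1scc(CN2CCN(c3cccc(F)c3)CC2)c1C(=O)c1ccc(Cl)cc1`, gives 1%.

All three share one core and differ only in the aryl group on an amine nitrogen in a ring. Compound 3 stands level with compound 2 at the digits shown, the two together the highest of the three numbers, and the remaining step is a number 1 percentage points higher from compound 1 to compound 3 (within the scatter). Every exchange of this aryl group so far left the read-out unmoved: a number 1 percentage points higher from compound 1 to compound 2 (within the scatter) and no change at the digits printed from compound 2 to compound 3 (within the scatter).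

Compound 4, `Nc1scc(CN2CCN(c3ccccc3F)CC2)c1C(=O)c1ccc(Cl)cc1`, is not yet measured. It differs from compound 3 only in where the fluorine sits on the phenyl ring: 2-fluorophenyl in place of 3-fluorophenyl on an amine nitrogen in a ring. The three measured steps all concern the same position of the molecule, and none of them went beyond the scatter, so no change beyond the scatter is expected for this assay from compound 3 to compound 4 either, a number 1 percentage points higher from compound 3 to compound 4 (within the scatter). Compound 4 is therefore estimated at 2%, within a range from -8% to 12%.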

Compound 4, a percentage reported as inhibition, at one concentration (the size of the read-out at that concentration, not a potency): 4%
For compound 4 the middle estimate is 2 percentage points below the measured one; measured number inside the range.
By their numbers in this assay, from the lowest: compounds 1, 2, 3 and 4 (each within the scatter of the next).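

Moving the fluorine on the phenyl ring changes no atom count, and in this assay the result is a small step (a number 3 percentage points higher from compound 3 to compound 4 (within the scatter)). This adds something new: the place of a single fluorine on the ring, and not only the choice of aryl group, leaves the read-out inside the scatter. The same holds when the 2-fluorophenyl group is set against the other two aryl groups (a number 3 percentage points higher from compound 2 to compound 4 (within the scatter); a number 4 percentage points higher from compound 1 to compound 4 (within the scatter)), and no measurement here explains this flat result.

The compounds shown leave open whether a non-aryl group on this ring nitrogen, such as a benzyl group or an acetyl group, would move the read-out at all. They also leave open whether replacing the free amine on the shared core with an amide would do so.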